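Aryl amide variation in a cathepsin S series

The source may report more compounds than this note shows. Statements on the series, on what has been measured and on what is new or still open speak of the compounds shown alone.

compound 1 `COc1ccc(NCCNC(=O)[C@H](CC2CCCCC2)NC(=O)c2ccc(-c3ccc(Cl)cc3)o2)cc1`: 7.1 nM
compound 2 `COc1ccc(NCCNC(=O)[C@H](CC2CCCCC2)NC(=O)c2ccc3ccccc3c2)cc1`: 5 nM

Going by the values given here, in an assay on isolated protein for inhibition of cathepsin S (Homo sapiens), at 37 degrees C, at pH 5.5 (on this read-out lower numbers stand for stronger inhibition and higher numbers for weaker inhibition), compound 2 gives 5 nM; the only other measured compound, compound 1, sits within the scatter of it, the step being a 1.4-fold lower number from compound 1 to compound 2 (0.15 log units; within the scatter). Compound 3 `COc1ccc(NCCNC(=O)[C@H](CC2CCCCC2)NC(=O)c2cccc(-c3ccccc3)c2)cc1` carries 3-phenylphenyl in place of naphthalen-2-yl on a carbonyl carbon. Among the compounds with values here, the single measured step, a 1.4-fold lower number from compound 1 to compound 2 (0.15 log units; within the scatter), also exchanges the aryl group on the carbonyl carbon and stays within the scatter, so the expected step from compound 2 to compound 3 is a 1.4-fold higher number from compound 2 to compound 3 (0.15 log units; within the scatter), with no change beyond the scatter. Compound 3 is therefore estimated at 7 nM, range 2.5 nM to 20 nM.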

Compound 3, inhibition constant: 2.9 nM
Beside the measured number, compound 3's estimate is 2.4-fold (0.38 log units) above it; the measured number falls inside the stated range.
By their numbers in this assay, from the lowest: compounds 3, 2 and 1 (each within the scatter of the next, the first and the last beyond it).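

In this assay the place on the carbonyl carbon takes 3-phenylphenyl as readily as naphthalen-2-yl, with a 1.7-fold lower number from compound 2 to compound 3 (0.24 log units; within the scatter) inside the scatter. Going by these compounds alone, the only step here beyond the scatter is modest: a 2.4-fold lower number from compound 1 to compound 3 (0.39 log units; beyond the scatter) between an all-carbon biaryl and 5-(4-chlorophenyl)furan-2-yl. Nothing available explains either step.

Open: whether this place tolerates an aryl group bearing an amine or a carboxylic acid, as the three groups shown carry neither. From the compounds shown here alone, the effect of a 4-phenylphenyl isomer also remains unknown.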